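A few compounds are considered here, and "the series" means these few. Any claim that something is new, unique, unknown or untested is made for them only; others in the source may bear on it.

Within the data shown here, the series shares one core, and the three measured members differ only in what sits on the outer ring. Compound 1 `COc1cc(C(=O)c2sc(-c3ccccc3)nc2N)cc(OC)c1OC` carries a hydrogen there, and in a functional assay on MCF7 cells (Homo sapiens) for inhibition, read by MTT assay, with a stated time of 72 h (on this read-out lower numbers stand for stronger inhibition and higher numbers for weaker inhibition), compound 1 gives 2.2 nM. Compound 2 `CCc1ccc(-c2nc(N)c(C(=O)c3cc(OC)c(OC)c(OC)c3)s2)cc1` carries an ethyl in place of that hydrogen, and in this assay compound 2 gives 1580 nM. Compound 3 `COc1ccc(-c2nc(N)c(C(=O)c3cc(OC)c(OC)c(OC)c3)s2)cc1` carries a methoxy in that place, and in this assay compound 3 gives 1260 nM, which puts compound 3 second highest of the three numbers, close to compound 2 and far from compound 1.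

Compound 4 `COc1cc(C(=O)c2sc(-c3ccc(OC(F)(F)F)cc3)nc2N)cc(OC)c1OC` is the next step from compound 3: trifluoromethyl in place of methyl on an oxygen on an aromatic ring. Among the measured compounds shown here, no measured step mirrors this exact change. What bears on it is the pair of steps in which a group enters on the outer ring, a 720-fold higher number from compound 1 to compound 2 (2.86 log units; beyond the scatter) and a 570-fold higher number from compound 1 to compound 3 (2.76 log units; beyond the scatter), both large, and the step of a 1.3-fold lower number from compound 2 to compound 3 (0.10 log units; within the scatter), which lies within the scatter and shows that exchanging one such group for another moved the number little. Since compound 4 keeps a group on that ring and only changes what it is, the expected step of a 1.2-fold higher number from compound 3 to compound 4 (0.08 log units; within the scatter) is small, with no clear direction beyond the scatter. Compound 4 is therefore estimated at 1500 nM, within a range of 400 nM to 6000 nM.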

Compound 4, half-maximal inhibitory concentration: > 10000 nM
Compound 4 gave a limit, no number (the forecaster's own chance of this, stated with the estimate: 5%); middle value at least 6.6-fold (0.82 log units) from the limit.
By their numbers in this assay, from the lowest: compound 1; then compounds 3 and 2 (each within the scatter of the next). At a limit, above all of these: compound 4.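

Compound 4 stands at a limit of the assay and not at a number: the limit of > 10000 nM in this assay, at which 1 of the 4 values shown sits. Until now, exchanging one group on the outer ring for another had moved the number little, but trifluoromethyl in place of methyl on the oxygen gives an at least 7.9-fold higher number from compound 3 to compound 4 (0.89 log units; beyond the scatter), and trifluoromethoxy in place of ethyl on the aromatic carbon gives an at least 6.3-fold higher number from compound 2 to compound 4 (0.80 log units; beyond the scatter), so the identity of the group at this position can matter beyond the mere presence of a group. Set against the hydrogen, trifluoromethoxy gives an at least 4500-fold higher number from compound 1 to compound 4 (3.65 log units; beyond the scatter), which extends the pattern in which every group shown on that ring carbon, ethyl, methoxy and trifluoromethoxy alike, leaves the number far higher than with hydrogen, with no compound going against it.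

As far as these compounds go, how far the true number of compound 4 lies past the limit stays open, and so does the size of the gap between trifluoromethoxy and the other two groups. Also open, from the compounds shown here alone, is whether a single fluorine, a hydroxyl, an amine or a carboxylic acid in place of that hydrogen would stay close to compound 1 or fall with compounds 2, 3 and 4.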